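The compounds below may be only part of what the source reports. "The series", "measured", "known", "first", "only" and "open" are said of these compounds alone.

Working notes on the series, values from a functional assay on RAW264.7 cells (Mus musculus), read by Griess assay, with a stated time of 15 min; on this read-out higher numbers stand for weaker inhibition and lower numbers for stronger inhibition:

- compound 1 `C[C@@H]1C[C@H](O)C2=C(CO)C(=O)O/C2=C/[C@@]2(C)CC[C@]1(O)O2`: 24700 nM
- compound 2 `C/C=C(\C)C(=O)O[C@H]1C[C@@H](C)[C@]2(O)CC[C@](C)(/C=C3/OC(=O)C(COC(C)=O)=C31)O2`: 2000 nM
- compound 3 `C=C(C)C(=O)O[C@H]1C[C@@H](C)[C@]2(O)CC[C@](C)(/C=C3/OC(=O)C(COC(C)=O)=C31)O2`: 6600 nM

Compound 3 holds the middle place of the three, with a higher number than compound 2 and a lower number than compound 1, both gaps beyond the scatter. Compound 4 `CC(=O)OCC1=C2/C(=C\[C@@]3(C)CC[C@](O)(O3)[C@H](C)C[C@@H]2O)OC1=O` is next, with hydrogen in place of (1-methylethenyl)carbonyl on an oxygen on a saturated carbon. Cut one bond further out, this reads ((1-methylethenyl)carbonyl)oxy to hydroxy.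

Among the measured compounds shown here, only one measured step touches the group that leaves: a 3.3-fold higher number from compound 2 to compound 3 (0.52 log units; beyond the scatter). That step swaps one acyl group for another and removes nothing, so it shows that the number in this assay moves with this group but does not size a removal. For the measured compounds named here, compound 1, at 24700 nM, is the only measured compound with hydroxy on that oxygen, but it carries a further change as well, so it is only a loose guide. A modest rise toward weaker inhibition, just beyond the scatter, is expected: the estimated change is a 2.4-fold higher number from compound 3 to compound 4 (0.38 log units; beyond the scatter). The estimate for compound 4 is 16000 nM, with an expected range of 7000 nM to 35000 nM.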

Compound 4, half-maximal inhibitory concentration: 2700 nM
Compound 4: middle estimate off by 5.9-fold (0.77 log units), on the high side; measured number below the stated range.
By their numbers in this assay, from the lowest: compounds 2 and 4 (each within the scatter of the next); then compound 3; then compound 1.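

In this assay the acyl group on this oxygen turns out not to be needed: taking (1-methylethenyl)carbonyl off to leave hydroxy gives a 2.4-fold lower number from compound 3 to compound 4 (0.39 log units; beyond the scatter) and so moves the number the other way from the rise seen with the acyl swap. With (1-methylprop-1-en-1-yl)carbonyl as the group removed, the result is a 1.4-fold higher number from compound 2 to compound 4 (0.13 log units; within the scatter) and this lies within the scatter, so at this position hydroxy and that acyl group cannot be told apart, and only (1-methylethenyl)carbonyl stands out, with the higher number. Among the compounds shown here, the high number of compound 1 can now be placed elsewhere, since hydroxy is common to both compounds and the single change of acetyl in place of hydrogen on the other oxygen gives a 9.1-fold lower number from compound 1 to compound 4 (0.96 log units; beyond the scatter), making that acetyl the larger lever seen so far.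

No measurement at hand bears on why these steps take the size they do. Still open, on these data alone, is how the number would respond on this oxygen to a longer acyl chain or a methyl group, and on the acetyl-bearing oxygen to acyl groups other than acetyl.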